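Oxazole in place of chlorofuran on the shared core

The compounds below may be only part of what the source reports. "The series", "measured", "known", "first", "only" and "open" are said of these compounds alone.

Measured compounds:
compound 1 `Nc1nc(-c2ccco2)nc2sc(CN3CC=CC3)cc12`, 290 nM
compound 2 `Nc1nc(-c2ccc(Cl)o2)nc2sc(CN3CC=CC3)cc12`, 780 nM

In an assay on CHO-K1 cells for antagonist activity at adenosine receptor A1 (Homo sapiens), read by a beta-galactosidase reporter, with stated times of 15 min and 6 h (a higher number here means a weaker inhibitor, a lower number a stronger inhibitor), compound 2 gives the higher of the two numbers; compound 1 stands nearest, with a 2.7-fold higher number from compound 1 to compound 2 (0.43 log units; beyond the scatter) between them.

Compound 3 `Nc1nc(-c2ncco2)nc2sc(CN3CC=CC3)cc12` is not yet measured. It differs from compound 2 by 1,3-oxazol-2-yl in place of 5-chlorofuran-2-yl on an aromatic carbon, at the position between two ring nitrogen atoms of the six-membered ring of the shared core. Going by the values given here, the chlorine leaves again, which in the single measured step moved the number, from compound 1 to compound 2, by a 2.7-fold higher number from compound 1 to compound 2 (0.43 log units; beyond the scatter); the ring exchange itself has no measured counterpart here. The step of a 1.3-fold lower number from compound 2 to compound 3 (0.11 log units; within the scatter) is therefore expected to stay near the scatter, with wide uncertainty in either direction. Compound 3 is estimated at 600 nM, within 150 nM to 2500 nM.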

Compound 3, inhibition constant: 3890 nM
Compound 3: the middle estimate sits 6.5-fold (0.81 log units) below what was measured; the measured number lies above the stated range.
By their numbers in this assay, from the lowest: compound 1; then compound 2; then compound 3.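

In this assay, the identity of the five-membered aromatic ring on this carbon between two ring nitrogen atoms counts for more than the chlorine: 1,3-oxazol-2-yl in place of furan-2-yl gives a 13-fold higher number from compound 1 to compound 3 (1.13 log units; beyond the scatter), a larger step than a 2.7-fold higher number from compound 1 to compound 2 (0.43 log units; beyond the scatter). Even against the already weaker 5-chlorofuran-2-yl, the exchange gives a 5.0-fold higher number from compound 2 to compound 3 (0.70 log units; beyond the scatter), which places 1,3-oxazol-2-yl on the weak side of both furans in this set of three. No measurement available here accounts for the loss that comes with this ring exchange.

Going by these compounds, it remains open whether a 1,3-thiazol-2-yl or a phenyl ring at this position would stand with the furans or with the oxazole. Also open, on these data alone, is whether a chlorine on the oxazole ring, or a morpholine on the side chain of the shared core, would shift these steps.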